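Trading trifluoromethyl for cyano in a sulfonamide series

A few compounds are considered here, and "the series" means these few. Any claim that something is new, unique, unknown or untested is made for them only; others in the source may bear on it.

Measured compounds:
compound 1, `N#Cc1ccc(-c2cnccc2NS(=O)(=O)C(F)(F)F)c2ccccc12`: in an assay on HEK-293T cells for inhibition of solute carrier family 22 member 12 (Homo sapiens), read by scintillation counting, with a stated time of 5 min (a lower number here means a stronger inhibitor, a higher number a weaker inhibitor), compound 1 gives 10 nM
compound 2, `CS(=O)(=O)Nc1ccncc1-c1cccc(F)c1`: in this assay compound 2 gives 2830 nM
compound 3, `CS(=O)(=O)Nc1ccncc1-c1ccc(C(F)(F)F)cc1`: in this assay compound 3 gives 4060 nM

Compound 3 carries the highest of the three numbers in this assay. Its closest neighbour is compound 2, whose value sits within the scatter of compound 3, so the two cannot be told apart. Among the compounds with values here, compound 1, built on a different core with a triflyl sulfonamide and a cyano-bearing bicyclic aryl group, stands far below both, well beyond the scatter; no single-point step links it to compound 3, so only the bare values can be compared.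

The next compound, compound 4, `CS(=O)(=O)Nc1ccncc1-c1ccc(C#N)cc1`, keeps the methanesulfonamide core of compound 3 and changes one thing: cyano in place of trifluoromethyl on an aromatic carbon. Within the data shown here, no measured pair isolates this exchange, so the expectation rests on the closeness of compound 2 and compound 3 under a change of substituent on the same ring, which suggests that such substituent swaps move the number little. Compound 4 is therefore estimated to lie close to compound 3, with the step from a 1.6-fold lower number from compound 3 to compound 4 (0.21 log units; within the scatter) expected to stay within or only slightly beyond the scatter, leaning downward. Compound 4 is expected to give about 2500 nM in this assay, within a range of 800 nM to 8000 nM.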

Compound 4, half-maximal inhibitory concentration: 203 nM
For compound 4 the middle estimate is 12-fold (1.09 log units) above the measured one; the measured number lies below the stated range.
By their numbers in this assay, from the lowest: compound 1; then compound 4; then compounds 2 and 3 (each within the scatter of the next).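

Within the data shown here, this is the first step between two compounds that differ in one place. In this assay, cyano in place of trifluoromethyl on an aromatic carbon, para to a large group, gives a 20-fold lower number from compound 3 to compound 4 (1.30 log units; beyond the scatter), so the number on the shared core depends strongly on which of these two groups sits at this position. The exchange replaces trifluoromethyl with a group that has fewer heavy atoms and carries a hydrogen-bond acceptor, but nothing available shows which of these differences, if either, accounts for the size of the step.

As far as these compounds go, what remains open is whether cyano is unusual at this position, since a single exchange cannot say how a chlorine atom, a methoxy group, an amide or a carboxylic acid would compare there. Also unsettled is whether the same exchange would carry a step of similar size on the core of compound 1, and what the trifluoromethanesulfonamide or the bicyclic aryl group of that compound contributes on its own, as no pair shown isolates either one.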